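The compounds below may be only part of what the source reports. "The series", "measured", "known", "first", "only" and "open" are said of these compounds alone.

Of the compounds shown here, three sharing one core have been measured in an assay on HEK293 cells for positive allosteric modulation of metabotropic glutamate receptor 5 (Homo sapiens), read by FLIPR, with a stated time of 1 h; on this read-out higher numbers stand for an effect only at larger amounts of compound and lower numbers for an effect already at smaller amounts. Compound 1 `CN1CCc2nc(C#Cc3ccccc3)sc2C1` gives 34 nM. Compound 2 `CC1CC(C(=O)N2CCc3nc(C#Cc4ccccc4)sc3C2)C1` gives 81 nM. Compound 3 `O=C(C1CCOCC1)N1CCc2nc(C#Cc3ccccc3)sc2C1` gives 290 nM, the highest of the three numbers: its step to its nearest neighbour is a 3.6-fold higher number from compound 2 to compound 3 (0.55 log units; beyond the scatter), and to the furthest it is an 8.5-fold higher number from compound 1 to compound 3 (0.93 log units; beyond the scatter).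

Compound 4 `CC(C)S(=O)(=O)N1CCc2nc(C#Cc3ccccc3)sc2C1` differs from compound 3 in one place: isopropylsulfonyl in place of (oxan-4-yl)carbonyl on an amine nitrogen in a ring. Among the measured compounds shown here, two measured steps bear on this. Replacing the methyl on the ring nitrogen with a carbonyl-bearing group raised the number, as seen in a 2.4-fold higher number from compound 1 to compound 2 (0.38 log units; beyond the scatter) and an 8.5-fold higher number from compound 1 to compound 3 (0.93 log units; beyond the scatter), and among the two carbonyl groups the one carrying a ring oxygen gave the higher number, as seen in a 3.6-fold higher number from compound 2 to compound 3 (0.55 log units; beyond the scatter). For the measured compounds named here, no measured step swaps a carbonyl for a sulfonyl, so direct guidance is lacking. The isopropylsulfonyl keeps a non-methyl cap on the nitrogen but brings no ring and no ring oxygen, so a modest downward step, a 1.9-fold lower number from compound 3 to compound 4 (0.29 log units; within the scatter), is expected, staying above compound 1. Compound 4 is therefore estimated at 150 nM, with a range from 50 nM to 500 nM.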

Compound 4, half-maximal effective concentration: > 10000 nM
Compound 4: a limit, no number; the forecaster's own chance of this, stated with the estimate: 5%; middle value at least 66-fold (1.82 log units) from the limit.
By their numbers in this assay, from the lowest: compound 1; then compound 2; then compound 3. At a limit, above all of these: compound 4.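

Compound 4 stands at a limit of the read-out, which is not a number: the limit of > 10000 nM in this assay, at which 1 of the 4 values shown sits.

Earlier changes on this amine nitrogen in a ring moved the number only modestly, but this change gives an at least 34-fold higher number from compound 3 to compound 4 (1.53 log units; beyond the scatter), along with an at least 120-fold higher number from compound 2 to compound 4 (2.09 log units; beyond the scatter) and an at least 290-fold higher number from compound 1 to compound 4 (2.46 log units; beyond the scatter). The position therefore accepts a methyl and both carbonyl-linked groups, yet it does not accept every group, and the counts do not predict this: isopropylsulfonyl and (oxan-4-yl)carbonyl have the same printed number of hydrogen-bond acceptors and donors.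

The compounds shown do not tell whether the sulfonyl link or the isopropyl on it accounts for the step. A methylsulfonyl or an isopropylcarbonyl group on the same nitrogen would separate the two.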